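The source may hold more compounds than are shown below. What is called first, only, known or untested is meant among the compounds shown, and "the series" means these compounds.

Measured compounds:
compound 1 `N#Cc1ccccc1COc1ccc(-c2cc(CN3CCN(Cc4ccc(C(F)(F)F)cc4)CC3)no2)cc1` — 5000 nM
compound 2 `N#Cc1cccc(COc2ccc(-c3cc(CN4CCN(c5ccc(C(F)(F)F)cn5)CC4)no3)cc2)c1` — 1700 nM

Both compounds were tested in a functional assay on Huh-7 cells (Homo sapiens) for antiproliferative activity, read by sulforhodamine B assay, with a stated time of 72 h; on this read-out lower numbers stand for stronger inhibition and higher numbers for weaker inhibition. Compound 2 gives 1700 nM, the lowest of the two numbers shown. For the measured compounds named here, its only neighbour is compound 1, which in this assay gives 5000 nM, a higher number by a gap that lies beyond the usual scatter. Compound 3 `N#Cc1cccc(COc2ccc(-c3cc(CN4CCN(C(=O)C5CC5)CC4)no3)cc2)c1` is the unmeasured compound. It differs from compound 2 in one place: cyclopropylcarbonyl in place of 5-(trifluoromethyl)pyridin-2-yl on an amine nitrogen in a ring. Going by the values given here, no pair of measured compounds differs in the same way, since both compound 1 and compound 2 carry a six-membered aromatic ring on that ring nitrogen, so no measured step speaks directly to this change. The step from compound 2 to compound 3 is therefore expected from the structural change alone, and the expectation is a move to a higher number, of moderate size and beyond the scatter, as a 2.6-fold higher number from compound 2 to compound 3 (0.42 log units; beyond the scatter). Compound 3 is estimated at 4500 nM in this assay, within a range from 1500 nM to 14000 nM.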

Compound 3, half-maximal inhibitory concentration: 2800 nM
Beside the measured number, compound 3's estimate is 1.6-fold (0.21 log units) above it; the measured number falls inside the stated range.
By their numbers in this assay, from the lowest: compounds 2, 3 and 1 (each within the scatter of the next, the first and the last beyond it).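

In this assay, putting cyclopropylcarbonyl in place of 5-(trifluoromethyl)pyridin-2-yl on the amine nitrogen in the ring gives a 1.6-fold higher number from compound 2 to compound 3 (0.22 log units; within the scatter), so this read-out does not separate the two compounds. Compound 1 and compound 2 both carry a six-membered aromatic ring on that nitrogen, whereas compound 3 shows that, in this one pair, such a ring is not needed to keep the number within the scatter of compound 2: a group of 5 heavy atoms, with a three-membered non-aromatic ring of carbon only, stands in for one of 10 heavy atoms. No measurement at hand bears on the reason for this result.

The compounds shown leave open whether the same would hold for a group with no ring at all on this nitrogen, such as an acetyl, a plain methyl or a longer alkyl chain, or for a chain ending in a carboxylic acid or a primary amine. They also leave open what the carbonyl and the cyclopropane ring each contribute, as the two enter together in compound 3.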